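Sulfonamide series: every measured point sits at a limit

A few compounds are considered here, and "the series" means these few. Any claim that something is new, unique, unknown or untested is made for them only; others in the source may bear on it.

Compound 3 `COc1ccc(S(=O)(=O)Nc2ccc3oc(-c4ccc(NC(=O)c5ccc(Cl)s5)cc4)nc3c2)cc1` carries a (5-chlorothiophen-2-yl)carbonyl on a nitrogen on an aromatic ring of the shared core. In an assay on isolated protein for inhibition of thiosulfate sulfurtransferase (Homo sapiens) (on this read-out higher numbers stand for weaker inhibition and lower numbers for stronger inhibition), compound 3 gives > 100000 nM, which is a limit of the assay and not a number. Compound 1 `O=S(=O)(Nc1ccc(-c2nc3cc(NS(=O)(=O)c4ccc(C(F)(F)F)cc4)ccc3o2)cc1)c1ccc(C(F)(F)F)cc1` gives > 100000 nM in this assay, likewise a limit. Compound 2 `COc1ccc(S(=O)(=O)Nc2ccc3oc(-c4ccc(NS(=O)(=O)c5cc(F)ccc5OC)cc4)nc3c2)cc1` gives > 100000 nM in this assay, also a limit. Among the measured compounds shown here, the only single-point step, a step that the two limits leave unreadable from compound 2 to compound 3, cannot be read; what the series shows is the limit of > 100000 nM in this assay, at which 3 of the 3 values shown sit. Compound 4 `COc1ccc(S(=O)(=O)Nc2ccc3oc(-c4ccc(NS(=O)(=O)c5cc(Br)ccc5OC)cc4)nc3c2)cc1` differs from compound 3 by (5-bromo-2-methoxyphenyl)sulfonyl in place of (5-chlorothiophen-2-yl)carbonyl on a nitrogen on an aromatic ring. For the measured compounds named here, no measured step bears on this change, so no direction can be read from it; the expected step of a number no higher from compound 3 to compound 4 (the limit leaves the size open) is therefore none. Compound 4 is expected to give 100000 nM in this assay, between 30000 nM and 300000 nM, most probably again as a limit.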

Compound 4, half-maximal inhibitory concentration: > 100000 nM
Compound 4 ended at the assay's limit; the forecaster's own chance of this, stated with the estimate: 85%; the middle value lies on the limit itself.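

Compound 4 gives > 100000 nM in this assay, which is a limit, so the steps from compound 2 and from compound 3 to compound 4 cannot be read. The series still shows only one thing: the limit of > 100000 nM in this assay, at which 4 of the 4 values shown sit. The compounds shown leave open which change, if any, would give a measurable value.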